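Swapping Nitro for Chloro on Two Related Bicyclic Cores

A few compounds are considered here, and "the series" means these few. Any claim that something is new, unique, unknown or untested is made for them only; others in the source may bear on it.

Of the compounds shown here, three have been tested in a functional assay on the whole organism for inhibition, with Rattus norvegicus as the target, at a dose of 30 mg/kg; on this read-out lower numbers stand for less inhibition and higher numbers for more inhibition at the one dose given (going by the name of the read-out). Compound 1 `O=[N+]([O-])c1ccc(-c2nc3cccnc3o2)cc1` gives 5%, and compound 3 `Clc1ccc(-c2nc3cccnc3o2)cc1` gives 14%. The change between them is chloro in place of nitro on an aromatic carbon, and the step was a number 9 percentage points higher from compound 1 to compound 3 (within the scatter). Compound 2 `O=[N+]([O-])c1cccc(-c2nc3ncccc3o2)c1` contains the same atoms as compound 1 joined differently; the difference between the two cores is not broken down here. In this assay compound 2 gives 21%. Compound 4 `Clc1cccc(-c2nc3ncccc3o2)c1` is not yet measured and arises from compound 2 by chloro in place of nitro on an aromatic carbon; here the place is meta to a group of 9 heavy atoms rather than para to a group of 9 heavy atoms, so this is the same kind of change, not the same. Because the measured step was a number 9 percentage points higher from compound 1 to compound 3 (within the scatter), the expected step is a number 6 percentage points higher from compound 2 to compound 4 (within the scatter). Compound 4 is therefore estimated at 27%, between 12% and 42%.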

Compound 4, a percentage reported as inhibition, in the whole organism at one dose (the size of the read-out at that dose, not a potency): 32%
Beside the measured number, compound 4's estimate is 5 percentage points below it; the range from low to high includes it.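

In this assay, chloro in place of nitro on the second core gives a number 11 percentage points higher from compound 2 to compound 4 (beyond the scatter). Set beside the earlier step, the change carries from one core to the other at much the same size: the same change on two cores in this assay, a number 9 percentage points higher (within the scatter) from compound 1 to compound 3 and a number 11 percentage points higher (beyond the scatter) from compound 2 to compound 4, 2 percentage points apart, within the scatter of two such steps This rests on only two pairs at a single dose, with the change sitting at a different place on the ring in each pair, so it does not show that the step would hold on a third core or explain why it occurs.

The compounds shown leave open what other groups at this place, such as an amine or a carboxylic acid, would give. They also leave open how the two cores compare when the attached group and its place are the same.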